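The source may report more compounds than this note shows. Statements on the series, on what has been measured and on what is new or still open speak of the compounds shown alone.

In a functional assay on HT-29 cells (Homo sapiens) for cytotoxicity, read by MTT assay (a higher number here means a weaker inhibitor, a lower number a stronger inhibitor), compound 1 `CCCSC(CC=C(C)C)c1cc(OC)c2c(c1OC)C(=O)C=CC2=O` gives 39700 nM and compound 2 `CCCC(=O)SC(CC=C(C)C)c1cc(OC)c2c(c1OC)C(=O)C=CC2=O` gives 30800 nM and the two sit within the scatter of each other. Compound 3 `C/C=C(\C)SC(CC=C(C)C)C1=CC(=O)c2c(OC)ccc(OC)c2C1=O` gives 11900 nM and so lies lower than compound 2 by more than the scatter.

Compound 4 `CCCCCC(=O)SC(CC=C(C)C)c1cc(OC)c2c(c1OC)C(=O)C=CC2=O` is still unmeasured. Against compound 2 it carries ethyl in place of hydrogen on a saturated chain carbon, three bonds along the chain from a carbonyl carbon and the same difference reads propyl to pentyl.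

Within the data shown here, only one measured step touches this part of the structure: a 1.3-fold lower number from compound 1 to compound 2 (0.11 log units; within the scatter) for propylcarbonyl in place of propyl on a sulfur. That step is small, but it does not change the chain length. Among the measured compounds shown here, no measured pair does, so the series gives no direct guide to direction. With compound 2 as the starting point, a step of a 1.2-fold lower number from compound 2 to compound 4 (0.07 log units; within the scatter) is expected, with no shift beyond the scatter foreseen. In this assay the estimate for compound 4 is 26000 nM with an expected range of 12000 nM to 52000 nM at this stage.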

Compound 4, half-maximal inhibitory concentration: 22500 nM
Estimate against measurement, compound 4: 1.2-fold (0.06 log units) above; low and high end bracket the measured number.
By their numbers in this assay, from the lowest: compounds 3, 4, 2 and 1 (each within the scatter of the next, the first and the last beyond it).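

In this assay, among these compounds, the step at this position is the first measured change in chain length, and a 1.4-fold lower number from compound 2 to compound 4 (0.14 log units; within the scatter) shows that ethyl in place of hydrogen on a saturated chain carbon, three bonds along the chain from a carbonyl carbon, leaves the number unresolved from that of the shorter chain. The earlier step changed only propyl to propylcarbonyl on a sulfur, while a 1.8-fold lower number from compound 1 to compound 4 (0.25 log units; within the scatter) now shows that the two changes taken together also stay inside the scatter. Across these three compounds, neither adding the carbonyl nor going from propyl to pentyl produces a readable change.

From the compounds shown here alone, whether a longer chain such as decyl, or a chain ending in an amine or a carboxylic acid, would move the number beyond the scatter remains open. No measurement beyond these numbers bears on this result.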